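Ester variation at the side-chain oxygen: cytotoxicity notes

A few compounds are considered here, and "the series" means these few. Any claim that something is new, unique, unknown or untested is made for them only; others in the source may bear on it.

The three measured esters share one core and differ only in the group on the carbonyl carbon. Compound 1 `CCCCC(=O)OCCc1c(-c2ccccc2Cl)c2cc(Cl)ccc2[nH]c1=O` carries the butyl ester; in an ADME assay on HepG2 2.2.15 cells (Homo sapiens) for cytotoxicity (on this read-out higher numbers stand for lower toxicity in this test and lower numbers for higher toxicity in this test), compound 1 gives 200000 nM, the highest of the three numbers. Compound 2 `O=C(O)CCCC(=O)OCCc1c(-c2ccccc2Cl)c2cc(Cl)ccc2[nH]c1=O` gives 110000 nM, and the step of a 1.8-fold lower number from compound 1 to compound 2 (0.26 log units; within the scatter) stays within the scatter. Compound 3 `O=C(OCCc1c(-c2ccccc2Cl)c2cc(Cl)ccc2[nH]c1=O)C1CCCC1` gives 46000 nM; the step of a 4.3-fold lower number from compound 1 to compound 3 (0.64 log units; beyond the scatter) is the largest change seen so far, and a 2.4-fold lower number from compound 2 to compound 3 (0.38 log units; beyond the scatter) points the same way.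

Compound 4 `COc1ccccc1/C=C/C(=O)OCCc1c(-c2ccccc2Cl)c2cc(Cl)ccc2[nH]c1=O` is not yet measured. It differs from compound 1 as follows: 2-(2-methoxyphenyl)ethenyl in place of butyl on a carbonyl carbon. Going by the values given here, no measured step introduces an aromatic ring or a double bond outside aromatic rings on this carbonyl carbon, so the only bearing comes from the exchange of butyl for cyclopentyl, where a larger ring-containing group in place of the chain lowered the number modestly. The change into compound 4 is a larger exchange at the same position, so a step of at least that size, downward, is expected: a 5.0-fold lower number from compound 1 to compound 4 (0.70 log units; beyond the scatter). For compound 4 the estimated value is therefore 40000 nM, with a range from 10000 nM to 150000 nM, the upper end allowing that the butyl-to-cyclopentyl step may overstate what a change at this position does.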

Compound 4, half-maximal cytotoxic concentration: 770000 nM
Beside the measured number, compound 4's estimate is 19-fold (1.28 log units) below it; measured number outside the range, above it.
By their numbers in this assay, from the lowest: compound 3; then compounds 2 and 1 (each within the scatter of the next); then compound 4.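

At this carbonyl carbon, the number in this assay can move in either direction: the exchange of butyl for 2-(2-methoxyphenyl)ethenyl gives a 3.9-fold higher number from compound 1 to compound 4 (0.59 log units; beyond the scatter), opposite in direction to the exchange of butyl for cyclopentyl, so a ring in the entering group does not by itself go with a lower number. Going by these compounds alone, the position also spans a wider range than the first three esters showed, with the only large step (a 17-fold higher number from compound 3 to compound 4 (1.22 log units; beyond the scatter)) and a further step beyond the scatter (a 7.0-fold higher number from compound 2 to compound 4 (0.85 log units; beyond the scatter)), leaving compound 4 highest of the four. Nothing available here accounts for the opposite directions of these exchanges on the same carbonyl carbon.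

The compounds shown do not separate the parts of the entering group, so the aromatic ring, the double bond outside it and the methoxy group remain unassigned; a plain 2-phenylethenyl ester or a saturated 2-(2-methoxyphenyl)ethyl ester would bear on this. Also open, from the compounds shown here alone, is how a longer chain or an amine on the same carbonyl carbon would read in this test.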